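The source may hold more compounds than are shown below. What is called first, only, known or untested is meant among the compounds shown, and "the series" means these compounds.

Compound 1 `Cc1ccc(N2CC[C@@H](NC(=O)Nc3ccccc3Br)C2)cc1F`: < 100 ug/mL, a limit
Compound 2 `O=C(Nc1ccccc1Br)N[C@@H]1CCN(c2ccc(F)c(F)c2)C1`: < 100 ug/mL, a limit

In a physicochemical assay for solubility (a higher number here means a more soluble compound, a lower number a less soluble compound), compound 2 has no exact number, only the limit < 100 ug/mL. Compound 3 `O=C(Nc1ccccc1Br)N[C@@H]1CCN(c2cccc(F)c2)C1` differs from it by hydrogen in place of fluoro on an aromatic carbon. Among the measured compounds shown here, the one measured step that bears on this change is a step that the two limits leave unreadable from compound 1 to compound 2. For the measured compounds named here, the only evidence on it is the limit of < 100 ug/mL in this assay, at which 2 of the 2 values shown sit. No step size can be carried over from it, so no step beyond the scatter is expected in this assay, in either direction. The expected step is a step that the limit leaves unreadable from compound 2 to compound 3. Compound 3 is estimated at 50 ug/mL, with an expected range of 15 ug/mL to 110 ug/mL.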

Compound 3, solubility: < 100 ug/mL
Compound 3: only a limit was reported (the forecaster's own chance of this, stated with the estimate: 85%); the middle value is on the limit's open side.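

Among the compounds shown here, compound 1, compound 2 and compound 3 each have only a limit in this assay, so no step between them can be read. As far as these compounds go, the actual solubility of each compound, and whether swapping methyl, fluoro or hydrogen changes it, remain open.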